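Methyl in Place of Methoxy on the Amide Ring

The compounds below may be only part of what the source reports. "The series", "measured", "known", "first", "only" and "open" are said of these compounds alone.

Three measured compounds share one core and differ only in the group on the amide nitrogen. Compound 1 `COc1ccc2c(=O)c(/C=C/C(=O)Nc3cccc(Cl)c3)coc2c1` carries a 3-chlorophenyl there, and in a functional assay on HeLa cells (Homo sapiens) for inhibition, read by MTT assay, with a stated time of 48 h (a lower number here means a stronger inhibitor, a higher number a weaker inhibitor), compound 1 gives 11900 nM. Compound 2 `COc1ccc2c(=O)c(/C=C/C(=O)NCc3ccc(F)cc3)coc2c1` carries a 4-fluorobenzyl instead; in this assay compound 2 reaches only the limit > 100000 nM. Compound 3 `COc1ccc2c(=O)c(/C=C/C(=O)Nc3ccccc3OC)coc2c1` carries a 2-methoxyphenyl; in this assay compound 3 likewise gives only the limit > 100000 nM, so compound 3 stands at the weak end of everything shown, without a number of its own. The step of an at least 8.4-fold higher number from compound 1 to compound 3 (0.92 log units; beyond the scatter) was at least modest, as was an at least 8.4-fold higher number from compound 1 to compound 2 (0.92 log units; beyond the scatter), while the step that the two limits leave unreadable from compound 2 to compound 3 cannot be sized because both values sit at the limit of > 100000 nM in this assay, at which 2 of the 3 values shown sit.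

Compound 4 `COc1ccc2c(=O)c(/C=C/C(=O)Nc3ccccc3C)coc2c1` differs from compound 3 by methyl in place of methoxy on an aromatic carbon. Going by the values given here, no measured step exchanges methoxy for methyl, so the measured steps speak only indirectly. Since compound 3 itself shows only the limit > 100000 nM, compound 4 is expected to remain weak, an estimated 100000 nM, plausibly between 20000 nM and 300000 nM. The expected step of a number no higher from compound 3 to compound 4 (the limit leaves the size open) is therefore estimated to be small, if readable at all.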

Compound 4, half-maximal inhibitory concentration: 7270 nM
Compound 4: the middle estimate sits 14-fold (1.14 log units) above what was measured, and the stated range ends above it.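

The change of methoxy to methyl on an aromatic carbon, ortho to a large group, gives an at least 13-fold lower number from compound 3 to compound 4 (1.13 log units; beyond the scatter), so a group in this place does not by itself cost activity, and the loss with the 2-methoxyphenyl goes with the methoxy, not the place. The 2-methylphenyl also stands clear of the 4-fluorobenzyl, with an at least 13-fold lower number from compound 2 to compound 4 (1.13 log units; beyond the scatter), while a 1.6-fold lower number from compound 1 to compound 4 (0.21 log units; within the scatter) leaves it level with the 3-chlorophenyl in this assay. The first two steps give only a minimum size, because compounds 2 and 3 have no number of their own: the limit of > 100000 nM in this assay, at which 2 of the 4 values shown sit.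

Going by these compounds, how a chlorine, a hydroxyl, an amine or a longer chain such as ethyl would fare in this same place stays open. Also open, on these data alone, is whether a methyl elsewhere on this ring would give a similar value.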